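Aryl swap on the weaker compound of the series

This account rests on a few compounds, and the source may have more. Where it says the series, first, only, none or still open, it means among the compounds named here.

In a functional assay on HepG2 cells (Homo sapiens) for inhibition, read by sulforhodamine B assay, with a stated time of 72 h (on this read-out lower numbers stand for stronger inhibition and higher numbers for weaker inhibition), compound 1 (`C[C@H](Nc1ncnc2[nH]cnc12)c1nn(-c2cccc(F)c2)c2cc(F)ccc12`) gives 32300 nM, the higher of the two numbers available. Compound 2 (`C[C@H](Nc1nc(N)nc(N)c1C#N)c1nn(-c2cccc(S(C)(=O)=O)c2)c2cc(Cl)ccc12`) gives 1880 nM, but it differs from compound 1 in more than one place, so the pair isolates no single change. Compound 3 (`C[C@H](Nc1ncnc2[nH]cnc12)c1nn(-c2ccncc2)c2cc(F)ccc12`) carries pyridin-4-yl in place of 3-fluorophenyl on an aromatic nitrogen. Among the compounds with values here, no measured step informs this change, so no shift beyond the scatter is expected in this assay. The expected step is a 1.1-fold lower number from compound 1 to compound 3 (0.03 log units; within the scatter). For compound 3 the estimated value is 30000 nM, with an expected range of 10000 nM to 80000 nM.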

Compound 3, half-maximal inhibitory concentration: 23100 nM
Beside the measured number, compound 3's estimate is 1.3-fold (0.11 log units) above it; the measured number falls inside the stated range.
By their numbers in this assay, from the lowest: compound 2; then compounds 3 and 1 (each within the scatter of the next).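

In this assay, within the data shown here, the change to pyridin-4-yl in place of 3-fluorophenyl on the aromatic nitrogen gives a 1.4-fold lower number from compound 1 to compound 3 (0.15 log units; within the scatter) and is the first single-change reading at this position. Replacing the carbon-only aromatic ring with a ring holding one hetero atom therefore leaves the number within the scatter, and both compounds stay in the same range. Nothing measured here bears on this result.

Going by these compounds, whether an amine, a carboxylic acid or a longer chain on this nitrogen would shift the number remains open. So does whether the same swap would read alike on the core of compound 2.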